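Methyl for Fluoro on the Amide Ring at Two Placements

The source may report more compounds than this note shows. Statements on the series, on what has been measured and on what is new or still open speak of the compounds shown alone.

Measured so far in a functional assay on BGC-823 cells (Homo sapiens) for inhibition, read by MTT assay, with a stated time of 72 h; on this read-out higher numbers stand for weaker inhibition and lower numbers for stronger inhibition:
compound 1, `Cc1ccc(N2CCCC2)c(C(=O)Nc2ccc(CNC(=O)OCc3cccnc3)cc2)c1`, gives only a limit of the assay: > 100000 nM
compound 2, `O=C(NCc1ccc(NC(=O)c2cc(F)ccc2N2CCCC2)cc1)OCc1cccnc1`, gives 14800 nM
compound 3, `O=C(NCc1ccc(NC(=O)c2ccc(F)cc2N2CCCC2)cc1)OCc1cccnc1`, gives 74500 nM

The value of compound 1 is a limit, (the limit of > 100000 nM in this assay, at which 1 of the 3 values shown sits). Compound 2 and compound 3 have the same atoms joined differently, and the difference between their cores is not broken down here; compound 3 shows the higher number of the two. Between compound 2 and compound 1 the change is methyl in place of fluoro on an aromatic carbon, and it gave an at least 6.7-fold higher number from compound 2 to compound 1 (0.82 log units; beyond the scatter).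

Compound 4, `Cc1ccc(C(=O)Nc2ccc(CNC(=O)OCc3cccnc3)cc2)c(N2CCCC2)c1`, is not yet measured. It differs from compound 3 by methyl in place of fluoro on an aromatic carbon. For the measured compounds named here, this is the same kind of change as the one from compound 2 to compound 1, but the surroundings differ: in compound 4 the methyl sits meta to a pyrrolidin-1-yl group and para to a large group, whereas in compound 1 it sits meta to a large group and para to a pyrrolidin-1-yl group. If the change behaves alike, the step is expected to be a 3.4-fold higher number from compound 3 to compound 4 (0.53 log units; beyond the scatter), resting on an at least 6.7-fold higher number from compound 2 to compound 1 (0.82 log units; beyond the scatter). Compound 4 is therefore estimated at 250000 nM, probably again only a limit, between 60000 nM and 1000000 nM.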

Compound 4, half-maximal inhibitory concentration: > 100000 nM
Compound 4: no number, only a limit; the forecaster's own chance of this, stated with the estimate: 70%; the middle value lies beyond the limit too.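

In this assay, compound 4 gives only a limit of the assay, > 100000 nM, not a true number. Methyl in place of fluoro on this core therefore amounts to an at least 1.3-fold higher number from compound 3 to compound 4 (0.12 log units; that floor lies within the scatter), so compound 4 may be weaker than compound 3 by much more than this floor, or by no more than ordinary assay noise. This means the result neither confirms that the change carries over from one core to the other with the same size nor shows that the two cores respond differently: the same change on two cores in this assay, an at least 6.7-fold higher number (0.82 log units; beyond the scatter) from compound 2 to compound 1 and an at least 1.3-fold higher number (0.12 log units; that floor lies within the scatter) from compound 3 to compound 4; the limit leaves it open whether they differ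

As far as these compounds go, with both methyl compounds sitting at the same assay limit, how far either lies beyond it remains unknown, and the two placements cannot be ranked against each other for the methyl compounds. From the compounds shown here alone, it also remains open whether a chloro group, a methoxy group or a plain hydrogen on the same aromatic carbon would give a measurable number on either core.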